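Replacing the substituent on the shared core of compound 1

The compounds below may be only part of what the source reports. "The series", "measured", "known", "first", "only" and "open" are said of these compounds alone.

Measured in a functional assay on NCI-H1993 cells (Homo sapiens) for inhibition, read by CCK-8 assay, with a stated time of 72 h; a higher number here means a weaker inhibitor, a lower number a stronger inhibitor:
- compound 1 `c1cnc2ccc(Cn3cnc4ncc(-c5cn[nH]c5)nc43)cc2c1`: 2890 nM
- compound 2 `OCCn1cc(-c2cnc3ncn(Cc4ccc5ncccc5c4)c3n2)cn1`: 2330 nM

The two values lie within the scatter of each other, with compound 2 at 2330 nM. Compound 3 `CN(C)c1cccc(-c2cnc3ncn(Cc4ccc5ncccc5c4)c3n2)c1` departs from compound 2 as follows: 3-(dimethylamino)phenyl in place of 1-(2-hydroxyethyl)-1H-pyrazol-4-yl on an aromatic carbon. For the measured compounds named here, the one measured step, a 1.2-fold lower number from compound 1 to compound 2 (0.09 log units; within the scatter), only adds 2-hydroxyethyl on an aromatic nitrogen and leaves the ring in place. It therefore bears only loosely on this replacement, and no data yet cover a six-membered aromatic ring of carbon only at this position. No change beyond the scatter is expected, though with wide uncertainty. The expected step is a 1.2-fold lower number from compound 2 to compound 3 (0.07 log units; within the scatter). For compound 3 the estimate is 2000 nM, within a range of 500 nM to 8000 nM.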

Compound 3, half-maximal inhibitory concentration: > 10000 nM
Compound 3: a limit, no number (the forecaster's own chance of this, stated with the estimate: 10%); middle value at least 5.0-fold (0.69 log units) away from the limit.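

In this assay compound 3 gives > 10000 nM, a limit and not a number: the limit of > 10000 nM in this assay, at which 1 of the 3 values shown sits.

This position does respond to the group it carries: 3-(dimethylamino)phenyl gives an at least 4.2-fold higher number from compound 2 to compound 3 (0.63 log units; beyond the scatter), and against the unsubstituted ring it gives an at least 3.4-fold higher number from compound 1 to compound 3 (0.53 log units; beyond the scatter). The earlier pair showed only a change on the aromatic nitrogen, with the 1H-pyrazol-4-yl ring kept in place, and that step stayed within the scatter.

From the compounds shown here alone, whether the loss lies with the six-membered aromatic ring of carbon only or with the dimethylamino group stays open. A plain phenyl at this place would separate the two.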